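A few compounds are considered here, and "the series" means these few. Any claim that something is new, unique, unknown or untested is made for them only; others in the source may bear on it.

Series notes. In an ADME assay on microsomes from liver (Mus musculus) for metabolic stability, read by LC-MS, using NADPH, with a stated time of 45 min, tested at 0.5 uM (on this read-out higher numbers stand for fast clearance and lower numbers for slow clearance), compound 1 `O=C(CCSc1nc2cc(Cl)ccc2o1)NC1CCCC1` gives "not determined" (no result reported): it stands nowhere on the numbers in hand, so there is no anchor for its own clearance. Two relatives do carry numbers. In this assay compound 2 `O=C(CSCc1nc2cc(Cl)ccc2o1)N1CCCC1` gives 71.8 mL/min/g, while compound 3 `CN(C(=O)CCSc1nc2cc(F)ccc2o1)C1CCS(=O)(=O)CC1` gives 0.6 mL/min/g. The step from compound 1 to compound 4 `CC1CCCN1C(=O)CCSc1nc2cc(Cl)ccc2o1` is 2-methylpyrrolidin-1-yl in place of cyclopentylamino on a carbonyl carbon. Among the compounds with values here, with no value for compound 1, no measured step fixes the size or direction of this change; the expectation is that compound 4 sits toward the fast end rather than near compound 3, given that compound 2 gives 71.8 mL/min/g on a closely related core. For compound 4 in this assay the estimate is 40 mL/min/g, within 10 mL/min/g to 120 mL/min/g.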

Compound 4, intrinsic clearance in a liver preparation (reported as CLH), per the amount of preparation that the assay uses: 98 mL/min/g
For compound 4 the middle estimate is 2.5-fold (0.39 log units) below the measured one; the measured number falls inside the stated range.
By their numbers in this assay, from the lowest: compound 3; then compounds 2 and 4 (each within the scatter of the next).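

In this assay, within the data shown here, compound 1 gives "not determined" (no result reported) so no step to compound 4 can be read. From the compounds shown here alone, whether 2-methylpyrrolidin-1-yl in place of cyclopentylamino changes clearance stays open. No evidence on hand bears on this result.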